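This account rests on a few compounds, and the source may have more. Where it says the series, first, only, none or still open, it means among the compounds named here.

Measured so far in an assay on HEK293 cells for agonist activity at Toll-like receptor 8 (Homo sapiens), read by a luciferase reporter, with a stated time of 6 h; a lower number here means that less compound is needed, a higher number that more compound is needed for the effect:
compound 1 `CCCCNc1nc(N)nc2c1CN(C(=O)c1ccccc1)CC2` gives 1.4 uM
compound 2 `CCCCNc1nc(N)nc2c1CCN(S(C)(=O)=O)C2` gives 0.8 uM
compound 3 `CCCCNc1nc(N)nc2c1CN(Cc1ccc(-c3ccccc3)cc1)CC2` gives 0.5 uM

All three compounds share the same core and differ only in the group attached to the ring nitrogen. Among the three numbers, compound 1 has the highest, which here means that the most compound is needed to switch on the reporter. Compound 2 lies within the usual scatter of compound 1, so no order can be read between those two. Compound 3 lies beyond the scatter, at a lower number than compound 1.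

Compound 4 `CCCCNc1nc(N)nc2c1CN(C(=O)c1ccncc1)CC2` has not yet been measured. It is compound 1 with one change: pyridin-4-yl in place of phenyl on a carbonyl carbon. Going by the values given here, no pair of measured compounds shows this kind of swap, so there is no step to lean on. A change of one ring atom in a group of the same size and shape is usually a small one, so the expectation is for no step beyond the scatter, in either direction. The expected step from compound 1 to compound 4 is a 1.2-fold lower number from compound 1 to compound 4 (0.07 log units; within the scatter), and compound 4 is estimated to give 1.2 uM, with a likely range from 0.4 uM to 3.5 uM.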

Compound 4, minimum effective concentration: > 25 uM
Compound 4 gave a limit, no number; the forecaster's own chance of this, stated with the estimate: 5%; middle value at least 20-fold (1.31 log units) from the limit.
By their numbers in this assay, from the lowest: compounds 3, 2 and 1 (each within the scatter of the next, the first and the last beyond it). At a limit, above all of these: compound 4.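

In this assay compound 4 sits at a limit of the assay, not at a number: the limit of > 25 uM in this assay, at which 1 of the 4 values shown sits. Pyridin-4-yl in place of phenyl on a carbonyl carbon gives an at least 17-fold higher number from compound 1 to compound 4 (1.25 log units; beyond the scatter), so a swap that keeps the count of heavy atoms and exchanges one ring carbon for a nitrogen is a large step here, not a small one. Going by these compounds alone, no earlier pair differing in one place could show that this place responds so sharply to a single ring atom.

What lies behind the step stays open, since nothing shown here gives a cause for it. Also open, going by these compounds, is how pyridin-3-yl or pyridin-2-yl would read on the same carbonyl carbon, and whether a benzoyl group carrying an amine or a methoxy group would stay with compound 1 or move with compound 4.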